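A few compounds are considered here, and "the series" means these few. Any claim that something is new, unique, unknown or untested is made for them only; others in the source may bear on it.

Measured compounds in an ADME assay on L6 cells (Rattus norvegicus) for cytotoxicity, read by fluorescence and resazurin assay, with a stated time of 72 h; on this read-out lower numbers stand for an effect already at smaller amounts and higher numbers for an effect only at larger amounts of compound:

- compound 1 `O=c1nc(-c2ccccc2)c2cc(-c3cccnc3)ccc2[nH]1`: > 50000 nM, a limit of the assay
- compound 2 `O=c1nc(-c2ccccc2)c2cc(-c3ccccc3)ccc2[nH]1`: > 50000 nM, a limit of the assay
- compound 3 `O=c1nc(-c2ccccc2)c2cc(-c3cncnc3)ccc2[nH]1`: > 50000 nM, a limit of the assay

Compound 3 stands where the other two stand: in this assay compound 3 gives only the limit > 50000 nM and no number. The steps among the three, a step that the two limits leave unreadable from compound 1 to compound 2, a step that the two limits leave unreadable from compound 1 to compound 3 and a step that the two limits leave unreadable from compound 2 to compound 3, are therefore all unreadable; what unites them is the limit of > 50000 nM in this assay, at which 3 of the 3 values shown sit.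

Compound 4 `O=c1nc(-c2ccccc2)c2cc(-c3cn[nH]c3)ccc2[nH]1` carries the next change at the same aromatic carbon: 1H-pyrazol-4-yl in place of pyrimidin-5-yl on an aromatic carbon. Within the data shown here, no measured step bears on it in a readable way; the three earlier replacements at this position left the read-out at the limit each time, and nothing separates one aryl group from another.

The expectation for compound 4 is therefore a value again beyond the limit, estimated at 60000 nM with a range from 30000 nM to 200000 nM. The expected step that the limit leaves unreadable from compound 3 to compound 4 is accordingly none beyond the scatter, with the main uncertainty being whether compound 4 yields a number at all.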

Compound 4, half-maximal effective concentration: > 50000 nM
Compound 4 was reported as a limit (the forecaster's own chance of this, stated with the estimate: 85%); the middle value does not contradict the limit.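

In this assay compound 4 gives > 50000 nM, which is a limit and not a number. Among these compounds, no step from compound 1, compound 2 or compound 3 to compound 4 can be read, and the series stays at one limit: the limit of > 50000 nM in this assay, at which 4 of the 4 values shown sit. The compounds shown leave open whether any group at this aromatic carbon gives a number in this assay.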